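Replacing the 4-fluorophenyl group of compound 3

This account rests on a few compounds, and the source may have more. Where it says the series, first, only, none or still open, it means among the compounds named here.

In a functional assay on MDA-MB-231 cells (Homo sapiens) for antiproliferative activity, read by MTT assay, with a stated time of 72 h (a lower number here means a stronger inhibitor, a higher number a weaker inhibitor), the measured compounds read as follows:

Compound 1 `O=C(CCc1cccc2c1B(O)OC2)Nc1cccc(Br)c1` gives 720 nM
Compound 2 `O=C(CCc1cccc2c1B(O)OC2)Nc1cccc(-c2ccccc2)c1` gives 220 nM
Compound 3 `O=C(CCc1cccc2c1B(O)OC2)Nc1cccc(-c2ccc(F)cc2)c1` gives 250 nM

On these numbers compound 3 is level with compound 2, since a 1.1-fold higher number from compound 2 to compound 3 (0.06 log units; within the scatter) stays within the scatter. The gap to the bromo compound is larger, and a 2.9-fold lower number from compound 1 to compound 3 (0.46 log units; beyond the scatter) lies beyond the scatter.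

Compound 4 `CSc1cccc(-c2cccc(NC(=O)CCc3cccc4c3B(O)OC4)c2)c1` keeps the shared core and the amide chain. It carries 3-(methylsulfanyl)phenyl in place of 4-fluorophenyl on an aromatic carbon of a six-membered aromatic ring of carbon only, meta to a large group 3-(methylsulfanyl)phenyl in place of 4-fluorophenyl on an aromatic carbon in the counted terms.

Two kinds of measured step bear on this change. Replacing bromo with an aromatic ring gave modest steps, a 3.3-fold lower number from compound 1 to compound 2 (0.51 log units; beyond the scatter) and a 2.9-fold lower number from compound 1 to compound 3 (0.46 log units; beyond the scatter) as shown, and compound 4 keeps such a ring. Adding fluoro to that ring gave only a 1.1-fold higher number from compound 2 to compound 3 (0.06 log units; within the scatter) within the scatter. Within the data shown here, no measured compound carries the methylsulfanyl group, so its effect remains unknown.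

The estimated change is a 1.0-fold lower number from compound 3 to compound 4 (0.02 log units; within the scatter) and no step beyond the scatter is expected. In this assay the estimated value for compound 4 is 240 nM with an expected range from 100 nM to 550 nM in all.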

Compound 4, half-maximal inhibitory concentration: 150 nM
The estimate for compound 4 lay 1.6-fold (0.20 log units) above the measured number; measured number inside the range.
By their numbers in this assay, from the lowest: compounds 4, 2 and 3 (each within the scatter of the next); then compound 1.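

In this assay, the aromatic ring that replaced bromo also accepts a methylsulfanyl group, something the fluoro of compound 3 could not show for a larger, sulfur-bearing group: a 1.5-fold lower number from compound 2 to compound 4 (0.17 log units; within the scatter) stays level, and a 1.7-fold lower number from compound 3 to compound 4 (0.22 log units; within the scatter) does too, even though this change swaps 4-fluorophenyl for 3-(methylsulfanyl)phenyl and so alters both the group and where it sits. Compound 4 therefore joins compound 2 and compound 3 as a third aryl compound clear of the bromo compound, with a 4.8-fold lower number from compound 1 to compound 4 (0.68 log units; beyond the scatter), and so far no substituent on the added ring has moved the number beyond the scatter in either direction. What lies behind these numbers cannot be said from the data at hand.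

Open, on these data alone, is whether a methoxy group, an amine or a carboxylic acid on the same ring would stay level with compound 4 or move beyond the scatter. Also open, as far as these compounds go, is whether a longer chain would keep these numbers, as all four compounds hold the amide chain and the shared core unchanged.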